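Replacing a methylamide with a pyrrolidine amide on the shared core

A few compounds are considered here, and "the series" means these few. Any claim that something is new, unique, unknown or untested is made for them only; others in the source may bear on it.

Measured so far:
compound 1, `CNC(=O)Cn1nc(N)c2c(C(F)(F)F)cc(-c3ccccc3)nc21`: 14400 nM
compound 2, `Nc1nn(CC(=O)NCCO)c2nc(-c3ccccc3)cc(C(F)(F)F)c12`: 96300 nM
compound 3, `Nc1nn(CC(=O)NC2CC2)c2nc(-c3ccccc3)cc(C(F)(F)F)c12`: "not active" (no number reported)

Of the compounds shown here, three with a shared core have been tested in a functional assay on DU-145 cells (Homo sapiens) for cytotoxicity, read by MTT assay, with a stated time of 24 h; a higher number here means a weaker inhibitor, a lower number a stronger inhibitor. Compound 1 gives the lowest of the two numbers, and its nearest neighbour is compound 2, which differs by a 6.7-fold higher number from compound 1 to compound 2 (0.83 log units; beyond the scatter). Compound 3, which carries a cyclopropyl on the amide nitrogen in place of the methyl of compound 1, gave no number at all and is described only as not active.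

Compound 4, `Nc1nn(CC(=O)N2CCCC2)c2nc(-c3ccccc3)cc(C(F)(F)F)c12`, is not yet measured. It differs from compound 1 by pyrrolidin-1-yl in place of methylamino on a carbonyl carbon. Among the measured compounds shown here, no measured step covers exactly this exchange. For the measured compounds named here, the only related step is the one from compound 1 to compound 2, where a larger group on the amide nitrogen raised the number, and compound 3 with its ring on the amide nitrogen returned no activity. Both point the same way, so a weaker result than compound 1 is expected, though the size is uncertain. The expected step is a 2.8-fold higher number from compound 1 to compound 4 (0.44 log units; beyond the scatter). For compound 4 the estimate in this assay is 40000 nM, within a range from 10000 nM to 200000 nM.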

Compound 4, half-maximal inhibitory concentration: 12200 nM
Estimate against measurement, compound 4: 3.3-fold (0.52 log units) above; the range from low to high includes it.
By their numbers in this assay, from the lowest: compounds 4 and 1 (each within the scatter of the next); then compound 2.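

In this assay the step of a 1.2-fold lower number from compound 1 to compound 4 (0.07 log units; within the scatter) shows that pyrrolidin-1-yl can stand in place of methylamino on this carbonyl carbon without a readable change, although the entering group has 5 heavy atoms against 2 and has no hydrogen-bond donor, while methylamino has 1. The earlier compounds shown here could suggest that any larger group on the amide nitrogen goes with a weaker result, but the step of a 7.9-fold lower number from compound 2 to compound 4 (0.90 log units; beyond the scatter) shows that the group on this carbonyl carbon can still matter, and compound 4, with its larger group, does not fit that simple reading. Compound 3, reported only as not active, also carries a ring, so the presence of a ring alone does not sort these compounds, and nothing available here explains these differences.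

The compounds shown leave open whether the tolerance seen with pyrrolidin-1-yl extends to a six-membered ring such as piperidin-1-yl or morpholin-4-yl, or to an open-chain dimethylamino group. They also leave open whether a carboxylic acid at the end of a longer chain would behave like the hydroxyethyl group of compound 2.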